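Estimating compound 4 from compound 1

A few compounds are considered here, and "the series" means these few. Any claim that something is new, unique, unknown or untested is made for them only; others in the source may bear on it.

In an ADME assay on microsomes from liver (Homo sapiens) for metabolic stability, read by LC-MS, with a stated time of 10 min, tested at 0.5 uM (on this read-out lower numbers stand for a less stable compound and higher numbers for a more stable compound), compound 1 (`c1cnc2c(c1)CCC[C@@H]2N(CCCN1CCNCC1)Cc1cc2ccccc2cn1`) gives 66%. That lies within the usual scatter of compound 2 (`CCN1CCN(CCCN(C[C@H]2Cc3ccccc3CN2)[C@H]2CCCc3cccnc32)CC1`) at 59%, while compound 3 (`c1ccc2c(c1)CN[C@@H](CN(CCCN1CCN(C3CC3)CC1)[C@H]1CCCc3cccnc31)C2`) is clearly lower at 21%. Compound 4 (`c1cnc2c(c1)CCC[C@@H]2N(CCCN1CCNCC1)Cc1nc2ccccc2[nH]1`) differs from compound 1 in one place: 1H-benzimidazol-2-yl in place of isoquinolin-3-yl on a saturated chain carbon bound to an amine nitrogen. Among the measured compounds shown here, the only measured step, a number 38 percentage points lower from compound 2 to compound 3 (beyond the scatter), comes from cyclopropyl in place of ethyl on an amine nitrogen in a ring, a different change elsewhere in the molecule. It gives no direction here, but it shows that one change can move this number far. No shift beyond the scatter is therefore expected in this assay, though the uncertainty is wide. The estimated step is a number 8 percentage points lower from compound 1 to compound 4 (within the scatter). Compound 4 is expected at 58%, within an estimated range from 30% to 80%.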

Compound 4, percent of the compound remaining: 63%
For compound 4 the middle estimate is 5 percentage points below the measured one; low and high end bracket the measured number.
By their numbers in this assay, from the lowest: compound 3; then compounds 2, 4 and 1 (each within the scatter of the next).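

In this assay, 1H-benzimidazol-2-yl in place of isoquinolin-3-yl gives a number 3 percentage points lower from compound 1 to compound 4 (within the scatter). So this place, on a saturated chain carbon bound to an amine nitrogen, takes a five-membered aromatic ring with a hydrogen-bond donor without a change that can be read in this number. Nothing measured here explains this outcome. Going by these compounds, whether a carboxylic acid or an open-chain amine at this place would leave the number as little changed stays open. So does whether this swap gives the same result in other compounds.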